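This account rests on a few compounds, and the source may have more. Where it says the series, first, only, none or still open, it means among the compounds named here.

Working notes on the series. Compound 1 `COc1ccc(S(=O)(=O)NC(=O)Nc2ccc(Cl)cc2)s1` and compound 2 `CCc1ccsc1S(=O)(=O)NC(=O)Nc1ccc(Cl)cc1` share a core and differ only in the group on the sulfonyl sulfur. Going by the values given here, in a functional assay on the whole organism (6C3HED cells, Mus musculus) for inhibition, at a dose of 150 mg/kg by the oral route (a lower number here means less inhibition, a higher number more inhibition at the dose given (going by the name of the read-out)), compound 1 gives 93%, and compound 2 gives 21%, the lowest of the two numbers so far; the one step, a number 72 percentage points lower from compound 1 to compound 2 (beyond the scatter), is large and shows that the group on the sulfonyl sulfur can move this assay strongly. Compound 3 `O=C(Nc1ccc(Cl)cc1)NS(=O)(=O)c1cc(Br)c(Br)s1` has not yet been measured. Its change from compound 2 is 4,5-dibromothiophen-2-yl in place of 3-ethylthiophen-2-yl on a sulfonyl sulfur. Among the compounds with values here, no measured step covers this change directly; the step from compound 1 to compound 2 only shows how much this position can matter, without saying in which direction a dibrominated ring moves. A rise from compound 2 is expected on balance, by a number 34 percentage points higher from compound 2 to compound 3 (beyond the scatter), because a number 72 percentage points lower from compound 1 to compound 2 (beyond the scatter) marks compound 2 as the low point. For compound 3 the estimated value is 55%, with a range from 15% to 95%.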

Compound 3, a percentage reported as inhibition, in the whole organism at one dose (the size of the read-out at that dose, not a potency): 25%
Estimate against measurement, compound 3: 30 percentage points above; low and high end bracket the measured number.
By their numbers in this assay, from the lowest: compounds 2 and 3 (each within the scatter of the next); then compound 1.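

The new compound shows that the low number at this position is not tied to the 3-ethylthiophen-2-yl group. In this assay, the change to 4,5-dibromothiophen-2-yl gives a number 4 percentage points higher from compound 2 to compound 3 (within the scatter), so these two groups on the sulfonyl sulfur cannot be told apart despite their different atoms. The 5-methoxythiophen-2-yl group now stands apart from both, with a number 68 percentage points lower from compound 1 to compound 3 (beyond the scatter), and nothing at hand explains this separation.

The compounds shown leave open whether the high number of compound 1 depends on the methoxy group itself or would also be seen with another group on the ring, such as an ethoxy group or an amine. They also leave open whether a ring carrying no substituent would stand with compound 1 or with compound 2 and compound 3.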